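The compounds below may be only part of what the source reports. "The series", "measured", "known", "first", "only" and "open" are said of these compounds alone.

Measured in a functional assay on DU-145 cells (Homo sapiens) for antiproliferative activity, read by propidium iodide staining, with a stated time of 96 h; a lower number here means a stronger inhibitor, a higher number a weaker inhibitor:
Compound 1 `CC(O)(COc1ccc(C(F)(F)F)cc1)C(=O)Nc1cccc(S(F)(F)(F)(F)F)c1`: 13600 nM
Compound 2 `CC(O)(COc1ccccc1C(F)(F)F)C(=O)Nc1cccc(S(F)(F)(F)(F)F)c1`: 52200 nM
Compound 3 `CC(O)(COc1ccc(OC(F)(F)F)cc1)C(=O)Nc1cccc(S(F)(F)(F)(F)F)c1`: 19100 nM

Compound 3, at 19100 nM, lies within the scatter of compound 1, and both stand below compound 2, at 52200 nM. Compound 4 `CC(O)(COc1ccc(C#N)cc1)C(=O)Nc1cccc(S(F)(F)(F)(F)F)c1` has cyano in place of trifluoromethoxy on an aromatic carbon. Among the measured compounds shown here, no measured compound carries cyano, so the evidence is indirect. For the measured compounds named here, the closest precedent is the exchange of trifluoromethyl for trifluoromethoxy at this place, which gave a 1.4-fold higher number from compound 1 to compound 3 (0.15 log units; within the scatter). The change to 2-(trifluoromethyl)phenyl gave a 3.8-fold higher number from compound 1 to compound 2 (0.58 log units; beyond the scatter), but it moves the group, and compound 4 keeps its place. The expected result in this assay is no change beyond the scatter, with an estimated 1.0-fold higher number from compound 3 to compound 4 (0.02 log units; within the scatter). For compound 4 the expected value is 20000 nM, with an estimated range of 8000 nM to 50000 nM.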

Compound 4, half-maximal inhibitory concentration: 42600 nM
Beside the measured number, compound 4's estimate is 2.1-fold (0.33 log units) below it; measured number inside the range.
By their numbers in this assay, from the lowest: compounds 1 and 3 (each within the scatter of the next); then compounds 4 and 2 (each within the scatter of the next).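

At this place, the two fluorinated groups had stayed within the scatter of each other, but cyano, which carries no fluorine, gives a step beyond the scatter in this assay from either of them (a 2.2-fold higher number from compound 3 to compound 4 (0.35 log units; beyond the scatter); a 3.1-fold higher number from compound 1 to compound 4 (0.50 log units; beyond the scatter)). The result lands within the scatter of the compound with the moved trifluoromethyl group (a 1.2-fold lower number from compound 2 to compound 4 (0.09 log units; within the scatter)), so exchanging the group here and moving it gave numbers of similar size. Nothing shown gives a reason for these differences. Going by these compounds, whether an amine or a carboxylic acid here would match cyano or the fluorinated groups remains open. So does the effect of cyano on another carbon of this ring.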